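This account rests on a few compounds, and the source may have more. Where it says the series, first, only, none or still open, it means among the compounds named here.

compound 1 `COc1ccc(Nc2ncnc3occ(C)c23)cc1` gives 445 nM
compound 2 `CCCN(c1ccc(OC)cc1)c1ncnc2occ(C)c12` gives 301 nM
compound 3 `CCc1ccc(N(C)c2ncnc3occ(C)c23)cc1` gives 287 nM

All three numbers come from a functional assay on Chorioallantoic membrane (Gallus gallus, strain Leghorn), read by microscopy, with a stated time of 40 h (a higher number here means a weaker inhibitor, a lower number a stronger inhibitor), and lie within the usual scatter of one another, so compound 3 stands level with compound 1 and compound 2 rather than apart from them.

Compound 4 `CNc1ccc(N(C)c2ncnc3occ(C)c23)cc1` keeps the shared core of compound 3 and changes one group. The difference is methylamino in place of ethyl on an aromatic carbon and amounts to methylamino in place of ethyl on an aromatic carbon, para to a large group. Among the compounds with values here, the only measured step is a 1.5-fold lower number from compound 1 to compound 2 (0.17 log units; within the scatter) for propyl in place of hydrogen on a nitrogen on an aromatic ring, and that change lies at a different place. Within the data shown here, no measured step tests a change on this aromatic carbon, so the data suggest no direction, and no shift beyond the scatter is expected. The estimated step is a 1.0-fold higher number from compound 3 to compound 4 (0.02 log units; within the scatter) and it is expected to stay small. For compound 4 the estimated value is 300 nM with an expected range from 120 nM to 750 nM in this assay once it is measured.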

Compound 4, half-maximal inhibitory concentration: 707 nM
Compound 4: the middle estimate sits 2.4-fold (0.37 log units) below what was measured; measured number inside the range.
By their numbers in this assay, from the lowest: compounds 3, 2, 1 and 4 (each within the scatter of the next, the first and the last beyond it).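

Methylamino in place of ethyl on an aromatic carbon, para to a large group, gives a 2.5-fold higher number from compound 3 to compound 4 (0.39 log units; beyond the scatter) in this assay, the first step in the series to lie beyond the scatter, so this position does respond to a change of group. Within the data shown here, the exchange keeps the count of heavy atoms but swaps a carbon for a nitrogen and brings in one hydrogen-bond donor and one hydrogen-bond acceptor, and the single pair cannot tell which of these differences matters. Nothing available accounts for the shift.

The compounds shown leave open whether a dimethylamino group or a hydroxyl group on this carbon would move the number the same way as methylamino. They also leave open how a longer chain such as propyl would compare with ethyl there.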